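One Group Swapped on an Amide-Type Nitrogen

A few compounds are considered here, and "the series" means these few. Any claim that something is new, unique, unknown or untested is made for them only; others in the source may bear on it.

In a functional assay on GBM3 cells (Homo sapiens) for antiproliferative activity, read by WST assay, with a stated time of 72 h (on this read-out higher numbers stand for weaker inhibition and lower numbers for stronger inhibition), compound 1 (`O=C(Nc1ccccc1F)Nc1cc2ncncc2cc1OCc1ccccc1`) gives 5900 nM and compound 2 (`O=C(Nc1cccc(Cl)c1)Nc1cc2ncncc2cc1OCc1cccc(Cl)c1`) gives 3500 nM as its reading. Compound 3 (`O=C(Nc1ccc(C(F)(F)F)cc1)Nc1cc2ncncc2cc1OCc1ccccc1`) gives 3700 nM and so sits within the scatter of both. Moving to compound 4 (`O=C(Nc1cccc(Cl)c1)Nc1cc2ncncc2cc1OCc1ccccc1`), which has not yet been measured, puts 3-chlorophenyl in place of 4-(trifluoromethyl)phenyl on an amide-type nitrogen and leaves the rest of the structure unchanged. For the measured compounds named here, the one measured step at this nitrogen is a 1.6-fold lower number from compound 1 to compound 3 (0.20 log units; within the scatter) and it stays within the scatter even though the group there is replaced. Compound 2 already carries 3-chlorophenyl at this nitrogen and gives 3500 nM as its reading, within the scatter of compound 3. No step beyond the scatter is therefore expected in this assay for this swap. The expected step is a 1.0-fold lower number from compound 3 to compound 4 (0.01 log units; within the scatter) on this estimate. Compound 4 is estimated at 3600 nM with an expected range from 2000 nM to 6500 nM when it is measured.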

Compound 4, half-maximal inhibitory concentration: 6400 nM
For compound 4 the middle estimate is 1.8-fold (0.25 log units) below the measured one; low and high end bracket the measured number.
By their numbers in this assay, from the lowest: compounds 2, 3, 1 and 4 (each within the scatter of the next).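

In this assay the swap at the amide-type nitrogen is a 1.7-fold higher number from compound 3 to compound 4 (0.24 log units; within the scatter) and the change from 2-fluorophenyl to 3-chlorophenyl at that nitrogen is a 1.1-fold higher number from compound 1 to compound 4 (0.04 log units; within the scatter) so 2-fluorophenyl, 4-(trifluoromethyl)phenyl and 3-chlorophenyl now all lie within the scatter of one another. A second kind of change also appears, hydrogen in place of chloro on an aromatic carbon, which is a 1.8-fold higher number from compound 2 to compound 4 (0.26 log units; within the scatter) and so stays within the scatter as well. Nothing measured here bears on what lies behind these numbers.

All the groups seen at this nitrogen are substituted phenyl rings. From the compounds shown here alone, whether a different kind of group there, such as a carboxylic acid, an amine or a longer chain, would produce a step beyond the scatter remains open.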